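Stereochemistry at the ring carbon in a pyrrolyl lactone pair

A few compounds are considered here, and "the series" means these few. Any claim that something is new, unique, unknown or untested is made for them only; others in the source may bear on it.

Measured so far:
compound 1, `C#CC[C@@H]1C[C@H](n2cccc2C(=O)CC)C(=O)O1`, gives 11.6% in a functional assay on N2a cells (Mus musculus), with a stated time of 48 h, tested at 0.01 uM; a lower number here means a weaker effect, a higher number a stronger effect of the compound at the concentration tested.
compound 2, `CC(=O)c1cccn1[C@H]1C[C@@H](CC#Cc2ccc([N+](=O)[O-])cc2)OC1=O`, gives -7.58% in this assay.

Compound 2 holds the lower of the two values recorded; its nearest neighbour on the numbers is compound 1, and the gap between them lies beyond the scatter. Going by the values given here, the two compounds differ in several places at once, so no single structural step between them can be isolated, and the gap can be read only as the difference of the two values.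

Compound 3, `CC(=O)c1cccn1[C@H]1C[C@H](CC#Cc2ccc([N+](=O)[O-])cc2)OC1=O`, has not yet been measured. Its difference from compound 2 is the two compounds have the same atoms and bonds and differ only in configuration as drawn: 1 of 2 stereo elements differ; a stereocentre at a saturated ring carbon is drawn R in compound 2 and S in compound 3. Among the compounds with values here, the data hold no pair that separates a single stereo element, so there is nothing to set the size or direction of this step against.

The step from compound 2 to compound 3 is expected to be a number 9.6 percentage points higher from compound 2 to compound 3 (within the scatter), which would keep compound 3 within the scatter of compound 2. On that basis the value of compound 3 in this assay is estimated at 2%, with a range from -10% to 14%.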

Compound 3, a percentage reported as activity, at one concentration (the size of the read-out at that concentration, not a potency): 1.43%
Compound 3: middle estimate off by 0.6 percentage points, on the high side; low and high end bracket the measured number.
By their numbers in this assay, from the lowest: compounds 2 and 3 (each within the scatter of the next); then compound 1.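

Turning the stereocentre at a saturated ring carbon from R to S gives, in this assay, a number 9 percentage points higher from compound 2 to compound 3 (within the scatter). Going by these compounds alone, this is the first pair that isolates a single stereo element, so the size of a configuration step at this centre can now be read directly, and here it does not exceed the usual scatter at the one concentration tested. The comparison is clean as a test of configuration alone, with no group entering or leaving, and the step can be assigned to this stereocentre for this reason: the fact that compounds 2 and 3 differ only in the configuration as drawn

Within the data shown here, the other stereo element has no matching pair, so whether a change of configuration there would give a step beyond the scatter remains open, as does whether the result for this pair would hold at any other concentration. On these data alone, it is also open whether the same configuration step would stay within the scatter with a different substituent in place of the nitro group, such as an amine or a carboxylic acid.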